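Swapping the lactam for a phenyl on the benzoxazole amide

The compounds below may be only part of what the source reports. "The series", "measured", "known", "first", "only" and "open" are said of these compounds alone.

Of the compounds shown here, two have so far been measured in an assay for inhibition of inositol hexakisphosphate kinase 2 (Homo sapiens), read by colorimetric assay, coupled enzyme assay and malachite green, with a stated time of 120 min, in the presence of a further agent that is not named here; a higher number here means a weaker inhibitor, a lower number a stronger inhibitor. Compound 1, `O=C(O)c1ccc2noc(-c3ccc(Oc4ncc(Cl)cc4Cl)cc3)c2c1`, gives 650 nM in this assay. Compound 2, `O=C1CCC(C(=O)Nc2ccc(-c3onc4ccc(C(=O)O)cc34)cc2)CN1`, gives 2390 nM in this assay; this is the highest of the two numbers, and the gap to compound 1 lies beyond the scatter. The two differ in more than one place, so the gap between them cannot be tied to a single change.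

Compound 3, `O=C(O)c1ccc2noc(-c3ccc(NC(=O)c4ccccc4)cc3)c2c1`, has not been measured. It keeps the amide of compound 2 and changes only the group on the carbonyl carbon: a group of 6 heavy atoms (6 carbon; one six-membered aromatic ring of carbon only) in place of a group of 7 heavy atoms (5 carbon, 1 nitrogen, 1 oxygen; one six-membered non-aromatic ring with 1 hetero atom), on a carbonyl carbon.

Among the compounds with values here, no step between measured compounds mirrors this exchange, so the size of the step is uncertain. Compound 1 at 650 nM shows that this core admits a lower number than compound 2 shows, and the expectation is that compound 3 moves toward it rather than away, by a modest amount that may not clear the scatter. The estimated step is a 1.8-fold lower number from compound 2 to compound 3 (0.26 log units; within the scatter). For compound 3 the expected value in this assay is 1300 nM, with a range from 450 nM to 4000 nM.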

Compound 3, half-maximal inhibitory concentration: 580 nM
Compound 3: the middle estimate sits 2.2-fold (0.35 log units) above what was measured, within the range that was stated.
By their numbers in this assay, from the lowest: compounds 3 and 1 (each within the scatter of the next); then compound 2.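

In this assay, the phenyl on the carbonyl carbon, in place of the six-membered non-aromatic ring with 1 hetero atom, gives a 4.1-fold lower number from compound 2 to compound 3 (0.61 log units; beyond the scatter), so a single exchange on this amide now accounts for a gap beyond the scatter, which the earlier pair could not show. The second comparison, benzamido in place of (3,5-dichloropyridin-2-yl)oxy on an aromatic carbon, gives a 1.1-fold lower number from compound 1 to compound 3 (0.05 log units; within the scatter), so in this assay these two different groups cannot be told apart. Nothing at hand gives a reason for the gain that came with the phenyl.

The exchange from compound 2 to compound 3 alters the ring type, the hetero atoms and the hydrogen-bond donor and acceptor counts together, so the compounds shown cannot say which of these differences matters, and a cyclohexyl or a pyridyl on the same carbonyl carbon would be needed to pull them apart. Also open, on these data alone, is how far the phenyl itself tolerates substitution, for instance by a chlorine or an amine, and whether the carboxylic acid shared by all three compounds can be replaced by a tetrazole.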